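A few compounds are considered here, and "the series" means these few. Any claim that something is new, unique, unknown or untested is made for them only; others in the source may bear on it.

In a functional assay on HepG2 cells (Homo sapiens) for cytotoxicity, read by MTT assay, with a stated time of 72 h (on this read-out higher numbers stand for weaker inhibition and lower numbers for stronger inhibition), compound 1 `O=C(Nc1ccc(Oc2ccnc3[nH]ccc23)cc1)c1nn(-c2ccc(Cl)cc2)ccc1=O` gives 19500 nM, and compound 2 `O=C(Nc1ccc(Oc2ccnc3[nH]ccc23)cc1)c1nn(-c2ccccc2)ccc1=O` gives 17800 nM. Compound 2 holds the lowest of the two numbers, yet the step of a 1.1-fold lower number from compound 1 to compound 2 (0.04 log units; within the scatter) leaves the pair within the scatter, so neither can be called stronger. Compound 3 `O=C(Nc1ccc(Oc2ccnc3[nH]ccc23)cc1)c1nn(-c2ccc(Br)cc2F)ccc1=O` differs from compound 2 by 4-bromo-2-fluorophenyl in place of phenyl on an aromatic nitrogen. Within the data shown here, the one measured step that touches this part of the molecule, a 1.1-fold lower number from compound 1 to compound 2 (0.04 log units; within the scatter), changed little. Compound 3 is therefore expected to show no step beyond the scatter in this assay, with the estimated change being a 1.0-fold higher number from compound 2 to compound 3 (0.00 log units; within the scatter). Compound 3 is estimated at 18000 nM, with a range from 8000 nM to 40000 nM.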

Compound 3, half-maximal inhibitory concentration: 46400 nM
Compound 3: middle estimate off by 2.6-fold (0.41 log units), on the low side; measured number outside the range, above it.
By their numbers in this assay, from the lowest: compounds 2 and 1 (each within the scatter of the next); then compound 3.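

The aryl group on this ring nitrogen can matter, which the swap of chloro for hydrogen did not show: in this assay there is a 2.6-fold higher number from compound 2 to compound 3 (0.42 log units; beyond the scatter) and also a 2.4-fold higher number from compound 1 to compound 3 (0.38 log units; beyond the scatter). Both steps are modest, but both go beyond the scatter, toward weaker inhibition with 4-bromo-2-fluorophenyl in this place. Nothing available explains this step. From the compounds shown here alone, the bromine and fluorine enter together, so the share of each stays open. Going by these compounds, it also stays open how an amine or a methoxy group on this phenyl ring would change the number.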